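A few compounds are considered here, and "the series" means these few. Any claim that something is new, unique, unknown or untested is made for them only; others in the source may bear on it.

Compound 2, whose structure is `Cn1cncc1CN1CC(N(CC2CCN(C(=O)OC(C)(C)C)CC2)S(=O)(=O)c2ccccn2)Cc2cc(C#N)ccc21`, stands highest of the three compounds measured in an ADME assay on Caco-2 cells (Homo sapiens) for permeability, in the apical to basolateral direction (a lower number here means that the compound crosses the layer more slowly, a higher number that the compound crosses the layer faster), where compound 2 gives 15.5 10^-6 cm/s. The two other measured compounds sit far below it: compound 1, with the structure `Cn1cncc1CN1CC(N(CC2CCN(C(=O)c3ccc(Cl)cc3)CC2)S(=O)(=O)c2ccccn2)Cc2cc(C#N)ccc21`, gives 0.5 10^-6 cm/s in this assay, and compound 3, with the structure `Cn1cncc1CN1CC(N(CC2CCN(C(=O)c3ccco3)CC2)S(=O)(=O)c2ccccn2)Cc2cc(C#N)ccc21`, gives 0.5 10^-6 cm/s. The measured steps show the gap plainly: there is a 31-fold higher number from compound 1 to compound 2 (1.49 log units; beyond the scatter), there is a 31-fold lower number from compound 2 to compound 3 (1.49 log units; beyond the scatter), and between the two lower compounds there is no change at the digits printed from compound 1 to compound 3 (within the scatter).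

Compound 4, whose structure is `CC(=O)N1CCC(CN(C2Cc3cc(C#N)ccc3N(Cc3cncn3C)C2)S(=O)(=O)c2ccccn2)CC1`, differs from compound 2 by methyl in place of tert-butoxy on a carbonyl carbon. Among the compounds with values here, the steps that bear on this change are the two that leave the tert-butoxy group at this carbonyl carbon, a 31-fold lower number from compound 2 to compound 3 (1.49 log units; beyond the scatter) and, read in reverse, a 31-fold higher number from compound 1 to compound 2 (1.49 log units; beyond the scatter); both were large and both pointed away from compound 2. Those steps brought in a ring, whereas here a methyl without a ring enters, so the size of the change is less certain. The author therefore expects a lower number for compound 4 than for compound 2, estimated as a 5.2-fold lower number from compound 2 to compound 4 (0.71 log units; beyond the scatter). Compound 4 is accordingly expected to give about 3 10^-6 cm/s in this assay, with a range from 0.8 10^-6 cm/s to 10 10^-6 cm/s.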

Compound 4, apparent permeability: 0.5 10^-6 cm/s
Beside the measured number, compound 4's estimate is 6.0-fold (0.78 log units) above it; measured number below the stated range.
By their numbers in this assay, from the lowest: compounds 1, 3 and 4 (each within the scatter of the next); then compound 2.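

Within the data shown here, until now, the fall from compound 2 had been seen only with ring-bearing groups on this carbonyl carbon, furan-2-yl and 4-chlorophenyl. In this assay, methyl, which has no ring, gives a fall of the same size, with a 31-fold lower number from compound 2 to compound 4 (1.49 log units; beyond the scatter), so a ring in the entering group is not required for it. Among the three groups that replace tert-butoxy, the numbers do not separate, with no change at the digits printed from compound 3 to compound 4 (within the scatter) and no change at the digits printed from compound 1 to compound 4 (within the scatter), which leaves compound 2 as the only one of the four compounds that stands apart, and nothing shown accounts for this gap.

The compounds shown leave open whether the high number of compound 2 goes with the oxygen on the carbonyl carbon or with the branched carbon group of tert-butoxy: methoxy would keep that oxygen without the branching, while tert-butyl would keep the branching without the oxygen. They also leave open where an amine on this carbonyl carbon, such as dimethylamino, would fall in this assay, at the level of compound 2 or with the other three.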